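The source may hold more compounds than are shown below. What is called first, only, known or untested is meant among the compounds shown, and "the series" means these compounds.

Measured compounds in a functional assay on cells for agonist activity at Free fatty acid receptor 1 (Mus musculus), read by FLIPR and calcium flux, with a stated time of 5 min; on this read-out lower numbers stand for smaller maximal responses and higher numbers for larger maximal responses:
compound 1 `Cc1nn(-c2ccccn2)c2cc(-c3ccc(CCC(=O)O)cc3)ccc12` gives 95%;
compound 2 `Cc1nn(-c2ccccn2)c2cc(-c3ccc(CC(C)(C)C(=O)O)cc3)ccc12` gives 18%;
compound 3 `Cc1nn(-c2ccccn2)c2cc(-c3ccc(CCC(=O)O)cc3F)ccc12` gives 105%.

Compound 1 ranks second highest of these three numbers; compound 3 sits within the usual scatter of it, while compound 2 sits far below it, a number 77 percentage points lower from compound 1 to compound 2 (beyond the scatter). Compound 4 `COc1nn(-c2ccccn2)c2cc(-c3ccc(CCC(=O)O)cc3)ccc12` differs from compound 1 only at the five-membered aromatic ring of the shared core: methoxy in place of methyl on an aromatic carbon. Neither measured step touches this place: a number 77 percentage points lower from compound 1 to compound 2 (beyond the scatter) came from putting 1-carboxy-1-methylethyl in place of carboxymethyl on a saturated chain carbon, and a number 10 percentage points higher from compound 1 to compound 3 (within the scatter) came from putting fluoro in place of hydrogen on a different aromatic carbon. No measured change speaks to this site, so no shift beyond the scatter is expected. The expected step is a number 5 percentage points lower from compound 1 to compound 4 (within the scatter), and compound 4 is estimated to give about 90%, within a range from 60% to 110%.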

Compound 4, largest response reached (reported as efficacy), in percent of the reference or control that the assay uses: 96%
Beside the measured number, compound 4's estimate is 6 percentage points below it, within the range that was stated.
By their numbers in this assay, from the lowest: compound 2; then compounds 1, 4 and 3 (each within the scatter of the next).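

In this assay, among the compounds shown here, this is the first measured change on this aromatic carbon of the five-membered ring: methoxy in place of methyl, which brings in one oxygen and one hydrogen-bond acceptor, gives a number 1 percentage points higher from compound 1 to compound 4 (within the scatter). So, for this pair, the maximal response is held when the group here is exchanged, whereas the chain change gave a number 77 percentage points lower from compound 1 to compound 2 (beyond the scatter). Nothing measured here explains this result.

Going by these compounds, whether an amine, a chloro group or the longer ethoxy would also hold the response on this carbon remains open. So does whether methoxy would behave the same alongside the fluoro group of compound 3.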